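This account rests on a few compounds, and the source may have more. Where it says the series, first, only, none or still open, it means among the compounds named here.

Measured compounds, in a functional assay on Bel-7402 cells (Homo sapiens) for cytotoxicity, read by MTT assay, with a stated time of 48 h; a higher number here means a weaker inhibitor, a lower number a stronger inhibitor:
compound 1 `CCn1cc(-c2nc3ccccc3o2)c(=O)c2cc(F)c(Cl)cc21` gives 28900 nM;
compound 2 `CCn1cc(-c2nc3ccccc3s2)c(=O)c2cc(F)c(N3CCNC(C)C3)c(F)c21` gives 15000 nM;
compound 3 `CCn1cc(-c2nc3ccc([N+](=O)[O-])cc3o2)c(=O)c2cc(F)c(Cl)cc21` gives 1800 nM.

Compound 1 and compound 3 share one core and differ in a single place: nitro in place of hydrogen on an aromatic carbon. That change made a large step, a 16-fold lower number from compound 1 to compound 3 (1.21 log units; beyond the scatter). Compound 2 has a different core, and the difference between the two cores is not broken down here; its value in this assay lies within the usual scatter of compound 1, so the two cannot be ordered.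

The unmeasured compound 4 `CCn1cc(-c2nc3ccc([N+](=O)[O-])cc3s2)c(=O)c2cc(F)c(N3CCNC(C)C3)c(F)c21` stands to compound 2 as compound 3 stands to compound 1: nitro in place of hydrogen on an aromatic carbon. The place of the change is described in the same words for both pairs, so this is the same change on a second core. It has been seen only once, so whether it carries over is open. Compound 4 is expected to give about 1500 nM, a step of roughly a 10-fold lower number from compound 2 to compound 4 (1.00 log units; beyond the scatter), which rests on the earlier step of a 16-fold lower number from compound 1 to compound 3 (1.21 log units; beyond the scatter) on the core of compound 1, with a wider range, 400 nM to 6000 nM. The core of compound 2 was not itself tested with this change, and the range is widened for that.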

Compound 4, half-maximal inhibitory concentration: 4100 nM
The estimate for compound 4 lay 2.7-fold (0.44 log units) below the measured number; the range from low to high includes it.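

On the core of compound 2, nitro in place of hydrogen on an aromatic carbon again lowers the number in this assay, with a 3.7-fold lower number from compound 2 to compound 4 (0.56 log units; beyond the scatter), so the direction of the change carries over to a second core. The size of the step does not carry over, and the gap between the two steps is larger than repeat measurements would explain: the same change on two cores in this assay, a 16-fold lower number (1.21 log units; beyond the scatter) from compound 1 to compound 3 and a 3.7-fold lower number (0.56 log units; beyond the scatter) from compound 2 to compound 4, 4.4-fold (0.64 log units) apart, beyond the scatter of two such steps. Within the data shown here, with only two cores, and with the difference between them not broken down, this does not show which part of the core goes with the smaller step, nor what size of step a third core would give.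

The compounds shown leave open whether an amine or a carboxylic acid on the same aromatic carbon would move the number as nitro does, and by how much on each core. They also leave open how the step would change if the two cores were altered one part at a time.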